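This account rests on a few compounds, and the source may have more. Where it says the series, first, only, none or still open, it means among the compounds named here.

Compound 1 `N#Cc1c(-c2ccccc2O)c(C#N)c(=O)n(/N=C/c2cn(-c3ccccc3)nc2-c2ccccc2)c1N` gives 162 ug/mL in an ADME assay on NIH3T3 cells (Mus musculus) for cytotoxicity, read by MTT assay (a lower number here means a stronger inhibitor, a higher number a weaker inhibitor), the highest of the two plain numbers here; compound 3 `N#Cc1c(-c2ccccc2C(F)(F)F)c(C#N)c(=O)n(/N=C/c2cn(-c3ccccc3)nc2-c2ccccc2)c1N` gives 56 ug/mL, and the step of a 2.9-fold lower number from compound 1 to compound 3 (0.46 log units; beyond the scatter) is beyond the scatter. Compound 2 `N#Cc1c(-c2ccc(F)cc2)c(C#N)c(=O)n(/N=C/c2cn(-c3ccccc3)nc2-c2ccccc2)c1N` reaches only a limit, > 200 ug/mL, which is the limit of > 200 ug/mL in this assay, at which 1 of the 3 values shown sits. The step of an at least 1.2-fold higher number from compound 1 to compound 2 (0.09 log units; that floor lies within the scatter) sits within the scatter, while an at least 3.5-fold lower number from compound 2 to compound 3 (0.55 log units; beyond the scatter) lies beyond it. Compound 4 `N#Cc1c(-c2ccc(C(F)(F)F)cc2)c(C#N)c(=O)n(/N=C/c2cn(-c3ccccc3)nc2-c2ccccc2)c1N` differs from compound 1 as follows: 4-(trifluoromethyl)phenyl in place of 2-hydroxyphenyl on an aromatic carbon. A trifluoromethyl placed ortho lowered the number in compound 3, whereas a para fluoro left compound 2 at the limit, so the expected step of a 1.5-fold lower number from compound 1 to compound 4 (0.17 log units; within the scatter) is small, leaning downward. Compound 4 is estimated at 110 ug/mL, expected between 45 ug/mL and 200 ug/mL.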

Compound 4, half-maximal inhibitory concentration: > 200 ug/mL
Compound 4 was reported as a limit (the forecaster's own chance of this, stated with the estimate: 25%); middle value at least 1.8-fold (0.25 log units) away from the limit.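

Moving the trifluoromethyl group around the phenyl ring gives an at least 3.5-fold higher number from compound 3 to compound 4 (0.55 log units; beyond the scatter) in this assay, so at this position the group's place on that ring matters, not just its presence. Exchanging 2-hydroxyphenyl for 4-(trifluoromethyl)phenyl gives an at least 1.2-fold higher number from compound 1 to compound 4 (0.09 log units; that floor lies within the scatter), a change not separable from the scatter. Compound 4 stands at a limit, as does compound 2, so the step between them cannot be read: the limit of > 200 ug/mL in this assay, at which 2 of the 4 values shown sit.

From the compounds shown here alone, whether an amine or a carboxylic acid on that phenyl ring would lower the number stays open.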